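Fluoro to Amino on a Series Sitting at the Limit

The compounds below may be only part of what the source reports. "The series", "measured", "known", "first", "only" and "open" are said of these compounds alone.

Three close relatives sharing one core have been tested in a functional assay on MCF7 cells (Homo sapiens) for cytotoxicity, read by MTT assay, with a stated time of 48 h; a lower number here means a stronger inhibitor, a higher number a weaker inhibitor. Compound 1 `Fc1ccc(Nc2nc(-c3cccc(F)c3)nc3ccc(F)cc23)cc1` gives > 50000 nM, which is a limit of the assay and not a measured number. Compound 2 `Fc1cccc(-c2nc(Nc3ccccc3Cl)c3cc(F)ccc3n2)c1` gives > 50000 nM, likewise only a limit. Compound 3 `Oc1cccc(Nc2nc(-c3cccc(F)c3)nc3ccc(F)cc23)c1` gives > 50000 nM, again a limit. Because of the limit of > 50000 nM in this assay, at which 3 of the 3 values shown sit, none of the steps among these three can be sized: a step that the two limits leave unreadable from compound 1 to compound 2, a step that the two limits leave unreadable from compound 1 to compound 3 and a step that the two limits leave unreadable from compound 2 to compound 3 are all unreadable. Compound 4 `Nc1ccc(Nc2nc(-c3cccc(F)c3)nc3ccc(F)cc23)cc1` has not yet been measured. It differs from compound 1 in one place: amino in place of fluoro on an aromatic carbon. Among the compounds with values here, no measured step bears on this change in a readable way; the three measured steps show only that three different groups on that nitrogen all left the compound at the limit. Compound 4 is therefore expected to behave much the same, with an expected step that the limit leaves unreadable from compound 1 to compound 4 that cannot be told apart from no change. Compound 4 is estimated at 60000 nM, within an expected range from 8000 nM to 300000 nM, and the measurement will most likely again be reported only as a limit.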

Compound 4, half-maximal inhibitory concentration: > 50000 nM
Compound 4: no number, only a limit; the forecaster's own chance of this, stated with the estimate: 75%; the middle value does not contradict the limit.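

Compound 4 gives only a limit in this assay, as do compound 1, compound 2 and compound 3, so no step among these compounds can be read: the limit of > 50000 nM in this assay, at which 4 of the 4 values shown sit.

Whether amino in place of fluoro, or any other change among these four compounds, makes any real difference remains open.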